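This account rests on a few compounds, and the source may have more. Where it says the series, first, only, none or still open, it means among the compounds named here.

Compound 2, `CCOC(=O)C1=C(C)NC(C)=C(C(=O)OCC)C1c1ccc(OCc2nnc(S)o2)cc1`, is measured in a functional assay on the whole organism (strain Wistar) for inhibition, with Rattus norvegicus as the target, read by paw edema, with stated times of 30 min and 0.5 h, at a dose of 20 mg/kg (on this read-out lower numbers stand for less inhibition and higher numbers for more inhibition at the one dose given (going by the name of the read-out)), where compound 2 gives 42.4%. Among the compounds with values here, of the two numbers known, compound 2 stands highest; its nearest neighbour is compound 1, `CCOC(=O)C1=C(C)NC(C)=C(C(=O)OCC)C1c1ccc(OCC(=O)NCc2ccccc2)cc1`, for which this assay shows 8.33%. Within the data shown here, the one step known, a number 34.1 percentage points higher from compound 1 to compound 2 (beyond the scatter), is the exchange of an open-chain carbamoyl group for a five-membered aromatic ring.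

Compound 3, `CCOC(=O)C1=C(C)NC(C)=C(C(=O)OCC)C1c1ccc(OCC(=O)NNC(=O)CCC(=O)O)cc1`, has not yet been measured in this assay. Its difference from compound 2 is a group of 11 heavy atoms (5 carbon, 2 nitrogen, 4 oxygen; no ring) in place of a group of 6 heavy atoms (2 carbon, 2 nitrogen, 1 oxygen, 1 sulfur; one five-membered aromatic ring with 3 hetero atoms), on a saturated chain carbon bound to an oxygen on an aromatic ring. Among the measured compounds shown here, this change runs the opposite way to the only measured step: the aromatic ring leaves again and an open chain enters, so the step from compound 1 to compound 2 is the only guide, and it points downward for compound 3. The entering chain is not the same as that of compound 1, so the size of the reversal is uncertain. Compound 3 is therefore expected to fall, with an estimated a number 22.4 percentage points lower from compound 2 to compound 3 (beyond the scatter). Compound 3 is estimated at 20%, between 5% and 40%.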

Compound 3, a percentage reported as inhibition, in the whole organism at one dose (the size of the read-out at that dose, not a potency): 34.9%
Compound 3: middle estimate off by 14.9 percentage points, on the low side, and the stated range covers the measured number.
By their numbers in this assay, from the lowest: compound 1; then compounds 3 and 2 (each within the scatter of the next).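

In this assay, an open chain on the saturated chain carbon bound to an oxygen on an aromatic ring does not by itself go with a low number: the step of a number 7.5 percentage points lower from compound 2 to compound 3 (within the scatter) is within the scatter, so compound 3 and compound 2 cannot be told apart, and the 5-sulfanyl-1,3,4-oxadiazol-2-yl ring is not required at this place for a read-out of this size. The amide of compound 1 stays in compound 3 and only the group on the amide-type nitrogen changes, with ((2-carboxyethyl)carbonyl)amino in place of benzyl giving the step of a number 26.6 percentage points higher from compound 1 to compound 3 (beyond the scatter), so among these compounds the low number of compound 1 goes with the benzyl on that nitrogen, not with an open chain as such. No measurement at hand accounts for either step.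

As far as these compounds go, it stays open whether the carboxylic acid at the end of the chain in compound 3 matters, and what its ethyl ester or a plain acetyl on that nitrogen would give. Also open, from the compounds shown here alone, is whether an amino group in place of the sulfanyl on the five-membered ring would keep the read-out of compound 2.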